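Pyrazole in place of cyanopyrrole: stability outlook

The source may report more compounds than this note shows. Statements on the series, on what has been measured and on what is new or still open speak of the compounds shown alone.

Compound 1 `N#Cc1cc(Nc2nc(N)nc(-c3cccc(-n4ccc5cc(C6CC6)cc(F)c5c4=O)c3CO)n2)cn1C1CC1`: 21%
Compound 2 `CCn1cc(Nc2nc(N)nc(-c3cccc(-n4ccc5cc(C6CC6)cc(F)c5c4=O)c3CO)n2)cc1C#N`: 32%

Within the data shown here, in an ADME assay on microsomes from liver (Mus musculus) for metabolic stability, read by LC-MS, using NADPH, with a stated time of 30 min, tested at 1.5 uM (a higher number here means that more of the compound is left, a lower number that less of the compound is left), compound 1 gives 21%, the lowest of the two numbers so far, and compound 2 gives 32%. Among the measured compounds shown here, the single measured step is a number 11 percentage points higher from compound 1 to compound 2 (beyond the scatter), a modest gain on exchanging one group on the aromatic nitrogen of the pyrrole.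

Compound 3 `Nc1nc(Nc2cn[nH]c2)nc(-c2cccc(-n3ccc4cc(C5CC5)cc(F)c4c3=O)c2CO)n1` differs from compound 1 by 1H-pyrazol-4-yl in place of 5-cyano-1-cyclopropyl-1H-pyrrol-3-yl on a nitrogen on an aromatic ring. The measured step bears on this only loosely: it shows that altering the substituent on that aromatic nitrogen can shift the read-out beyond the scatter, but here the cyclopropyl, the nitrile and the pyrrole itself all leave and a pyrazole with a hydrogen-bond donor enters. For the measured compounds named here, no measured pair covers such a change, so the direction is uncertain; a modest upward step is taken as the working expectation, with a wide range.

Compound 3 is therefore expected to give 35%, estimated between 15% and 60%. The expected step is a number 14 percentage points higher from compound 1 to compound 3 (beyond the scatter).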

Compound 3, percent of the compound remaining: 39%
Compound 3: the middle estimate sits 4 percentage points below what was measured; low and high end bracket the measured number.
By their numbers in this assay, from the lowest: compound 1; then compounds 2 and 3 (each within the scatter of the next).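

At this position, on a nitrogen on an aromatic ring, exchanging the whole 5-cyano-1-cyclopropyl-1H-pyrrol-3-yl for 1H-pyrazol-4-yl in this assay gives a number 18 percentage points higher from compound 1 to compound 3 (beyond the scatter) and shows that neither the nitrile nor the cyclopropyl is required for this level of read-out. The same pyrazole in place of 5-cyano-1-ethyl-1H-pyrrol-3-yl gives a number 7 percentage points higher from compound 2 to compound 3 (within the scatter) and so separates neither group from the other in this read-out. No supporting evidence bears on these numbers.

On these data alone, the ring, the nitrile and the substituent on the ring nitrogen all change together, so their separate shares stay open. Also open, as far as these compounds go, is how a methyl on the pyrazole nitrogen or a nitrile on the pyrazole ring would read here.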